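The compounds below may be only part of what the source reports. "The series", "measured", "known", "first", "only" and "open" are said of these compounds alone.

Compound 1 `CN(C)CCn1cnnc1-c1cc(Oc2ccc(NC(=O)Nc3ccc(Cl)c(C(F)(F)F)c3)cc2F)ccn1`: 3760 nM
Compound 2 `CN(C)CCn1cnnc1-c1cc(Oc2ccc(NC(=O)Nc3ccc(F)c(F)c3)cc2F)ccn1`: > 50000 nM
Compound 3 `CN(C)CCn1cnnc1-c1cc(Oc2ccc(NC(=O)Nc3ccc(F)c(Cl)c3)cc2F)ccn1`: 7580 nM

These values come from an ADME assay on WI-38 cells (Homo sapiens) for cytotoxicity, read by MTT assay, with a stated time of 72 h; on this read-out lower numbers stand for stronger inhibition and higher numbers for weaker inhibition. For compound 2, > 50000 nM is a limit of the assay, not a number. Compound 1 stands level with compound 3 within the scatter, as a 2.0-fold higher number from compound 1 to compound 3 (0.30 log units; within the scatter) shows.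

Compound 4 `CN(C)CCCn1cnnc1-c1cc(Oc2ccc(NC(=O)Nc3ccc(Cl)c(C(F)(F)F)c3)cc2F)ccn1` keeps the core of compound 1 but changes 2-(dimethylamino)ethyl to 3-(dimethylamino)propyl: (dimethylamino)methyl in place of dimethylamino on a saturated chain carbon, two bonds along the chain from an aromatic nitrogen. Both steps away from compound 1, an at least 13-fold higher number from compound 1 to compound 2 (1.12 log units; beyond the scatter) and a 2.0-fold higher number from compound 1 to compound 3 (0.30 log units; within the scatter), swap only the phenyl group on the amide-type nitrogen. Neither touches this chain, so they offer no direct guide, and no change beyond the scatter is expected in this assay. The expected step is a 1.1-fold lower number from compound 1 to compound 4 (0.03 log units; within the scatter). Compound 4 is estimated at 3500 nM, with an expected range from 1500 nM to 9000 nM.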

Compound 4, half-maximal inhibitory concentration: 7910 nM
The estimate for compound 4 lay 2.3-fold (0.35 log units) below the measured number; the range from low to high includes it.
By their numbers in this assay, from the lowest: compounds 1, 3 and 4 (each within the scatter of the next, the first and the last beyond it). At a limit, above all of these: compound 2.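

Among these compounds, compound 4 gives the first look at the chain on the aromatic nitrogen, as the earlier steps changed only the phenyl group on the amide-type nitrogen. In this assay, 3-(dimethylamino)propyl in place of 2-(dimethylamino)ethyl gives a 2.1-fold higher number from compound 1 to compound 4 (0.32 log units; beyond the scatter), so this position does register, though only modestly. Nothing shown here explains this step.

As far as these compounds go, whether a longer chain ending in the same dimethylamino would move the number further stays open, as does the effect of a morpholine in place of dimethylamino. Also open, from the compounds shown here alone, is whether this chain change would give a similar step with the other phenyl groups.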